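Estimating an unglycosylated analogue from three measured compounds

The compounds below may be only part of what the source reports. "The series", "measured", "known", "first", "only" and "open" are said of these compounds alone.

Compound 1 `C=C1[C@H](O)C[C@@H]2[C@](C)(CO)[C@H](O)CC[C@@]2(C)[C@@H]1CCC1=CCOC1=O` gives 22500 nM in a functional assay on HL-60 cells (Homo sapiens) for antiproliferative activity, read by trypan blue exclusion; a lower number here means a stronger inhibitor of growth, a higher number a weaker inhibitor of growth. Compound 2 `C=C1[C@@H](CCC2=CCOC2=O)[C@]2(C)CC[C@@H](O)[C@@](C)(CO)[C@H]2C[C@@H]1O` gives 25200 nM. Compound 3 `C=C1CC[C@@H]2[C@](C)(CO[C@@H]3O[C@H](CO)[C@@H](O)[C@H](O)[C@H]3O)CCC[C@@]2(C)[C@@H]1CCC1=CCOC1=O` gives 26700 nM.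

Going by the values given here, all three numbers sit within the scatter of one another, and compound 3 stands among them with no step to either neighbour beyond that scatter. Among the compounds with values here, the single measured step, a 1.1-fold higher number from compound 1 to compound 2 (0.05 log units; within the scatter), rests on the fact that compounds 1 and 2 differ only in configuration as drawn (the fact that compounds 1 and 2 differ only in the configuration as drawn). Compound 4 `C=C1CC[C@@H]2[C@](C)(CO)CCC[C@@]2(C)[C@@H]1CCC1=CCOC1=O` differs from compound 3 in hydrogen in place of 3,4,5-trihydroxy-6-(hydroxymethyl)oxan-2-yl on an oxygen on a saturated carbon. Within the data shown here, no measured step covers the loss of a sugar, so no direction is expected beyond the scatter, and the expected step is a 1.2-fold lower number from compound 3 to compound 4 (0.08 log units; within the scatter). Compound 4 is therefore estimated at 22000 nM, with a range from 7000 nM to 70000 nM.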

Compound 4, concentration for 50% growth inhibition: 20000 nM
Compound 4: the middle estimate sits 1.1-fold (0.04 log units) above what was measured; the range from low to high includes it.
By their numbers in this assay, from the lowest: compounds 4, 1, 2 and 3 (each within the scatter of the next).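

In this assay hydrogen in place of 3,4,5-trihydroxy-6-(hydroxymethyl)oxan-2-yl on this oxygen gives a 1.3-fold lower number from compound 3 to compound 4 (0.13 log units; within the scatter) and so shows that this position takes either the whole sugar or the bare hydroxyl with no difference beyond the scatter. The earlier compounds shown here, with only a change of configuration measured between them, could not show this. Nothing given here explains the step.

The compounds shown leave open whether an acetyl group, a carboxylic acid or an amine at this place would read differently. They also leave open whether the sugar would matter on the core of compound 1.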